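This account rests on a few compounds, and the source may have more. Where it says the series, first, only, none or still open, it means among the compounds named here.

Compound 2 `O=C(CSc1nnnn1-c1cccc2ccccc12)N/N=C/c1ccc(Cl)cc1` is one of three measured members of a small series built on a shared core. In an ADME assay on MT4 cells (Homo sapiens) for cytotoxicity, read by MTT assay (a lower number here means that less compound is tolerated, a higher number that more compound is tolerated), compound 2 gives > 295000 nM, which is a limit of the assay and not a number. Compound 1 `O=C(CSc1nnnn1-c1cccc2ccccc12)N/N=C/c1ccco1` carries furan-2-yl where compound 2 carries 4-chlorophenyl. In this assay compound 1 also sits at a limit, giving > 330000 nM. Among the measured compounds shown here, compound 3 `O=C(CSc1nnnn1-c1cccc2ccccc12)N/N=C/c1ccccc1Cl`, with 2-chlorophenyl, is the only member with a read number, giving 69700 nM in this assay. The step that the two limits leave unreadable from compound 1 to compound 2 cannot be sized, whereas an at least 4.2-fold lower number from compound 2 to compound 3 (0.62 log units; beyond the scatter) and an at least 4.7-fold lower number from compound 1 to compound 3 (0.67 log units; beyond the scatter) both show the 2-chlorophenyl compound being tolerated less. Compound 4 `COc1ccc(/C=N/NC(=O)CSc2nnnn2-c2cccc3ccccc23)cc1` arises from compound 2 by methoxy in place of chloro on an aromatic carbon. For the measured compounds named here, none of the measured steps touches this place, and both compounds that lack the 2-chlorophenyl group sit at their limits. He therefore expects no step beyond the scatter, a step that the limit leaves unreadable from compound 2 to compound 4. For compound 4 he estimates 300000 nM, between 100000 nM and 900000 nM, most likely again reported only as a limit.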

Compound 4, half-maximal cytotoxic concentration: > 298000 nM
Compound 4: no number, only a limit (the forecaster's own chance of this, stated with the estimate: 70%); the middle value lies beyond the limit too.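

With methoxy in place of chloro on this aromatic carbon, para to a large group, compound 4 also ends at a limit of this assay and not at a number: the limit of > 298000 nM in this assay, at which 1 of the 4 values shown sits.

The steps linking compound 4 with compound 1 and with compound 2 cannot be read, so this change has no size that can be stated. The one readable step is an at least 4.2-fold higher number from compound 3 to compound 4 (0.63 log units; beyond the scatter), which leaves compound 3, with 2-chlorophenyl, as the only compound shown with a read number.

The compounds shown leave open whether an amine or a carboxylic acid on this aromatic carbon would give a read number. They also leave open whether compound 2 and compound 4 differ at all, as neither has a read value.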